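Swapping Fluoro for Trifluoromethyl on a Weakly Cytotoxic Series

This account rests on a few compounds, and the source may have more. Where it says the series, first, only, none or still open, it means among the compounds named here.

Three compounds share one core and differ only in a group on the six-membered aromatic ring of carbon only. Compound 1 `c1ccc(CO/N=C2/C(c3c[nH]c4ccccc34)=Nc3ccccc32)cc1` carries hydrogen there, and in a functional assay on T-24 cells (Homo sapiens) for cytotoxicity, read by MTT assay, with a stated time of 2 days (on this read-out higher numbers stand for weaker inhibition and lower numbers for stronger inhibition), compound 1 gives 12200 nM. Compound 2 `Cc1ccc(CO/N=C2/C(c3c[nH]c4ccccc34)=Nc3ccccc32)cc1` carries methyl, and in this assay compound 2 gives 23500 nM. Compound 3 `Fc1ccc(CO/N=C2/C(c3c[nH]c4ccccc34)=Nc3ccccc32)cc1` carries fluoro, and in this assay compound 3 gives 23100 nM. The number for compound 3 sits between the other two, yet every step is small: a 1.9-fold higher number from compound 1 to compound 2 (0.28 log units; within the scatter), a 1.9-fold higher number from compound 1 to compound 3 (0.28 log units; within the scatter) and a 1.0-fold lower number from compound 2 to compound 3 (0.01 log units; within the scatter). Whatever has been placed at this carbon so far has made no difference that can be told apart from repeated measurements.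

Compound 4 `FC(F)(F)c1ccc(CO/N=C2/C(c3c[nH]c4ccccc34)=Nc3ccccc32)cc1` takes the change one stage further: trifluoromethyl in place of fluoro on an aromatic carbon. Among the measured compounds shown here, the steps that bear on it are the two that already swap groups at the same carbon, and neither left the scatter, so these data give no reason to expect the move to trifluoromethyl to behave differently. The expected step is therefore a 1.1-fold higher number from compound 3 to compound 4 (0.03 log units; within the scatter), which means no change beyond the scatter. Compound 4 is estimated at 25000 nM in this assay, with a range from 10000 nM to 60000 nM.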

Compound 4, half-maximal inhibitory concentration: 18900 nM
Compound 4: the middle estimate sits 1.3-fold (0.12 log units) above what was measured, within the range that was stated.
By their numbers in this assay, from the lowest: compounds 1, 4, 3 and 2 (each within the scatter of the next).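

In this assay trifluoromethyl brings 4 heavy atoms where fluoro has 1, yet swapping one for the other gives a 1.2-fold lower number from compound 3 to compound 4 (0.09 log units; within the scatter) and the same group gives a 1.2-fold lower number from compound 2 to compound 4 (0.09 log units; within the scatter) when it replaces methyl and a 1.5-fold higher number from compound 1 to compound 4 (0.19 log units; within the scatter) when it replaces hydrogen. Among the compounds shown here, this is the first sign that a clearly bigger group at this carbon still leaves the number inside the scatter, so hydrogen, methyl, fluoro and trifluoromethyl cannot be told apart here, and all four compounds remain equally weak within the limits of the measurement. No measurement offered alongside these compounds speaks to why this carbon responds so little.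

Going by these compounds, all four groups carry no hydrogen-bond donors or acceptors and no net charge by the count given for the last change, so it stays open whether a group of another kind at this carbon, such as an amine, a carboxylic acid or a longer chain, would move the number beyond the scatter. On these data alone, it also stays open whether the same groups would behave alike on another carbon of this ring, since every one shown sits para to a large group.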